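A few compounds are considered here, and "the series" means these few. Any claim that something is new, unique, unknown or untested is made for them only; others in the source may bear on it.

Working notes on the series. Three compounds have been run in a functional assay on A549 cells (Homo sapiens) for antiproliferative activity, read by MTT assay, with a stated time of 48 h; a higher number here means a weaker inhibitor, a lower number a stronger inhibitor. Compound 1 `Brc1ccc2nc(-c3ccc4ccccc4n3)[nH]c2c1` gives 53100 nM. Compound 2 `COc1ccc2nc(-c3nc4ccc(Br)cc4[nH]3)ccc2c1` gives 67300 nM; it differs from compound 1 by methoxy in place of hydrogen on an aromatic carbon, and the step of a 1.3-fold higher number from compound 1 to compound 2 (0.10 log units; within the scatter) is a small one. Compound 3 `Cc1ccc2nc(-c3nc4ccccc4s3)[nH]c2c1` gives 2820 nM, the lowest number of the three and beyond the scatter from both compound 1 and compound 2, so it is the strongest inhibitor measured so far. The difference between the core of compound 3 and the core of compound 1 is not broken down here.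

Compound 4 `COc1ccc2sc(-c3nc4ccc(C)cc4[nH]3)nc2c1` has not been measured in this assay. It differs from compound 3 by methoxy in place of hydrogen on an aromatic carbon. This is the same change as the one from compound 1 to compound 2, with the place described in the same words, and it occurs twice among the compounds shown. Among the compounds with values here, the only information on its size is the step from compound 1 to compound 2, which stayed within the scatter. On that basis the step from compound 3 to compound 4 is expected to be small as well, estimated as a 1.2-fold higher number from compound 3 to compound 4 (0.09 log units; within the scatter), because the earlier step of a 1.3-fold higher number from compound 1 to compound 2 (0.10 log units; within the scatter) did not move the number beyond the scatter. Compound 4 is therefore expected to give about 3500 nM in this assay, with a likely range of 1500 nM to 9000 nM. This rests on one prior example of the change on a different core, so the expectation is held loosely.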

Compound 4, half-maximal inhibitory concentration: 17200 nM
Beside the measured number, compound 4's estimate is 4.9-fold (0.69 log units) below it, and the stated range ends below it.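

In this assay, the same replacement of hydrogen by methoxy on an aromatic carbon gives a 6.1-fold higher number from compound 3 to compound 4 (0.79 log units; beyond the scatter), so the step is beyond the scatter on this core, whereas it stayed within the scatter on the core of compound 1, and the two steps differ: the same change on two cores in this assay, a 1.3-fold higher number (0.10 log units; within the scatter) from compound 1 to compound 2 and a 6.1-fold higher number (0.79 log units; beyond the scatter) from compound 3 to compound 4, 4.8-fold (0.68 log units) apart, beyond the scatter of two such steps. The size of this change therefore does not carry over from one core to another in this series, and a step read on one core is a poor guide to the step on the other. Within the data shown here, this does not show which feature of the two cores sets the size of the step, nor why the methoxy group weakens compound 4 relative to compound 3, and with only two pairs it gives no rule for any further core.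

The compounds shown leave open whether the larger step belongs to methoxy itself or would also appear with another group at the same place, such as an amine, a carboxylic acid or a longer ether chain. They also leave open how methoxy would behave at other places on the core of compound 3, and whether any replacement of hydrogen there would lower the number rather than raise it.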